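Changing the Aryl Group: From Compound 3 to Compound 4

The compounds below may be only part of what the source reports. "The series", "measured", "known", "first", "only" and "open" are said of these compounds alone.

Compound 1, `COc1ccc(N2CCN(Cn3nc(-c4ccc5c(c4)OCCO5)oc3=S)CC2)cc1`, in a functional assay on HepG2 cells (Homo sapiens) for antiproliferative activity, read by MTT assay, with a stated time of 48 h (on this read-out higher numbers stand for weaker inhibition and lower numbers for stronger inhibition), gives only a limit of the assay, > 50000 nM.
Compound 2, `COc1ccccc1N1CCN(Cn2nc(-c3ccc4c(c3)OCCO4)oc2=S)CC1`, in this assay gives 15500 nM.
Compound 3, `O=[N+]([O-])c1ccc(N2CCN(Cn3nc(-c4ccc5c(c4)OCCO5)oc3=S)CC2)cc1`, in this assay gives 29500 nM.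

Compound 3 holds the higher of the two numbers given in this assay, yet its nearest neighbour is compound 2 and the gap a 1.9-fold higher number from compound 2 to compound 3 (0.28 log units; within the scatter) lies within the scatter. Compound 1 sits at the limit of > 50000 nM in this assay, at which 1 of the 3 values shown sits, so for it only a floor is known: an at least 1.6-fold lower number from compound 1 to compound 3 (0.22 log units; that floor lies within the scatter). The change to compound 4, `S=c1oc(-c2ccc3c(c2)OCCO3)nn1CN1CCN(c2cccc(Cl)c2)CC1`, is 3-chlorophenyl in place of 4-nitrophenyl on an amine nitrogen in a ring. Among the measured compounds shown here, no measured step exchanges a nitro for a chlorine. For the measured compounds named here, the steps that bear on it are the other aryl swaps on the same ring nitrogen: an at least 3.2-fold lower number from compound 1 to compound 2 (0.50 log units; beyond the scatter), at least modest, and a 1.9-fold higher number from compound 2 to compound 3 (0.28 log units; within the scatter), within the scatter. Together they show that varying this aryl group moves the number by modest amounts at most. Relative to compound 3, the step expected for compound 4 is a 1.2-fold lower number from compound 3 to compound 4 (0.07 log units; within the scatter). The estimate for compound 4 is 25000 nM, with a range from 8000 nM to 80000 nM.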

Compound 4, half-maximal inhibitory concentration: > 50000 nM
Compound 4: a limit, no number; the forecaster's own chance of this, stated with the estimate: 30%; middle value at least 2.0-fold (0.30 log units) away from the limit.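

Compound 4 ends at a limit of the assay and not at a number, the second compound to do so: the limit of > 50000 nM in this assay, at which 2 of the 4 values shown sit. The clearest step is an at least 3.2-fold higher number from compound 2 to compound 4 (0.50 log units; beyond the scatter), so in this assay the aryl group on this ring nitrogen can matter, and the 2-methoxyphenyl of compound 2 stands apart from both limit compounds, though not from compound 3. The step of an at least 1.6-fold higher number from compound 3 to compound 4 (0.22 log units; that floor lies within the scatter) does not separate 3-chlorophenyl from 4-nitrophenyl, and the step between the two limit compounds cannot be read.

The compounds shown leave open whether the methoxy group itself or its place on the phenyl ring sets compound 2 apart from compound 1. They also leave open how an unsubstituted phenyl, or a phenyl carrying an amine or a carboxylic acid, would read on this ring nitrogen.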